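This account rests on a few compounds, and the source may have more. Where it says the series, first, only, none or still open, it means among the compounds named here.

Compound 1 `COc1cccc(-c2ccc3ccc(C)nc3c2)c1`: 860 nM
Compound 2 `Cc1ccc2ccc(-c3cccc(CO)c3)cc2n1`: 8700 nM
Compound 3 `Cc1ccc2ccc(-c3cccc(Cl)c3)cc2n1`: 14000 nM

These three compounds share one core and differ only in the group carried on the outer six-membered ring. In a functional assay on CHO cells for inhibition of metabotropic glutamate receptor 5 (Rattus norvegicus), read by FLIPR and calcium flux (on this read-out lower numbers stand for stronger inhibition and higher numbers for weaker inhibition), compound 3 gives the highest number of the three: compound 2 sits within the scatter of it, while compound 1 lies well apart, with a 16-fold higher number from compound 1 to compound 3 (1.21 log units; beyond the scatter).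

Compound 4 `Cc1ccc2ccc(-c3cccc(O)c3)cc2n1` has not yet been measured. It differs from compound 3 by hydroxy in place of chloro on an aromatic carbon. Going by the values given here, two measured steps bear on this exchange. Replacing methoxy by chloro gave a 16-fold higher number from compound 1 to compound 3 (1.21 log units; beyond the scatter); replacing hydroxymethyl by chloro gave a 1.6-fold higher number from compound 2 to compound 3 (0.21 log units; within the scatter). An oxygen-bearing group on this ring thus went with a lower number in compound 1, while the hydrogen-bond donor in compound 2 changed little. A hydroxy group combines both features, so a decrease in this assay is expected, of a size between those two steps, expected as a 4.0-fold lower number from compound 3 to compound 4 (0.60 log units; beyond the scatter). Compound 4 is therefore estimated at 3500 nM, with a range from 900 nM to 14000 nM.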

Compound 4, half-maximal inhibitory concentration: 19000 nM
For compound 4 the middle estimate is 5.4-fold (0.73 log units) below the measured one; the measured number lies above the stated range.
By their numbers in this assay, from the lowest: compound 1; then compounds 2, 3 and 4 (each within the scatter of the next, the first and the last beyond it).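

In this assay, hydroxy and chloro on this aromatic carbon cannot be told apart, with a 1.4-fold higher number from compound 3 to compound 4 (0.13 log units; within the scatter), so bringing in a hydrogen-bond donor here gave no gain over a group that has none. Taking only the methyl off the oxygen of the methoxy group has a large effect, with a 22-fold higher number from compound 1 to compound 4 (1.34 log units; beyond the scatter), so an oxygen on the ring is not enough by itself, and methoxy stands apart from the other three groups. Hydroxy and hydroxymethyl differ only modestly, with a 2.2-fold higher number from compound 2 to compound 4 (0.34 log units; beyond the scatter), a small step beside that one.

Nothing measured here explains why methoxy alone gives the low number. The compounds shown leave open whether a longer chain on the oxygen, such as ethoxy, would keep that low number, and whether an amine or a carboxylic acid here would behave like methoxy or like the other groups.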